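Swapping One Ring Group on a Shared Core

This account rests on a few compounds, and the source may have more. Where it says the series, first, only, none or still open, it means among the compounds named here.

Results so far in a functional assay on PC-3 cells (Homo sapiens) for antiproliferative activity, read by CCK-8 assay, with a stated time of 6 days; on this read-out higher numbers stand for weaker inhibition and lower numbers for stronger inhibition
- compound 1 `CCN(c1ccc(C#N)c(Cl)c1)c1cc(-n2cnc3ccccc32)ccc1C` gives 8160 nM
- compound 2 `CCN(c1ccc(C#N)c(Cl)c1)c1cc(-c2ccnn2C)ccc1C` gives 7290 nM
- compound 3 `CCN(c1ccc(C#N)c(Cl)c1)c1cc(C2=CCCCC2)ccc1C` stands as "not determined" (no result reported) and has no reported result

Compound 3 has no number, so it gives no starting point for a step. Compound 4 `CCN(c1ccc(C#N)c(Cl)c1)c1cc(-c2cn[nH]c2)ccc1C` carries 1H-pyrazol-4-yl in place of cyclohex-1-en-1-yl on an aromatic carbon, and the counted difference is 1H-pyrazol-4-yl in place of cyclohex-1-en-1-yl on an aromatic carbon in full.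

Within the data shown here, only one measured step bears on this change. It is a 1.1-fold lower number from compound 1 to compound 2 (0.05 log units; within the scatter) and involves 1-methyl-1H-pyrazol-5-yl in place of 1H-benzimidazol-1-yl at the same place. That is a different swap, so it offers only a weak guide, but this exchange of ring groups stayed within the scatter. Among the measured compounds shown here, no step from compound 3 can be expected in this assay without a number for it. Compound 4 is instead expected to lie near compound 2 at 7290 nM in this assay, with no firm direction. For compound 4 the estimated value is 6000 nM as the middle, with an expected range from 2000 nM to 16000 nM in this assay.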

Compound 4, half-maximal inhibitory concentration: 15300 nM
Beside the measured number, compound 4's estimate is 2.6-fold (0.41 log units) below it; the range from low to high includes it.
By their numbers in this assay, from the lowest: compounds 2, 1 and 4 (each within the scatter of the next, the first and the last beyond it).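

Among these compounds, at this place on the shared core, 1H-pyrazol-4-yl in place of 1-methyl-1H-pyrazol-5-yl gives a 2.1-fold higher number from compound 2 to compound 4 (0.32 log units; beyond the scatter) in this assay, the first exchange here to pass the scatter, though only modestly. Against 1H-benzimidazol-1-yl, the same group gives a 1.9-fold higher number from compound 1 to compound 4 (0.27 log units; within the scatter), so the position responds to the choice of ring group only slightly, and only one of these pairs is separated. The two pyrazole names differ in both the methyl group and the ring atom that carries the attachment, so the step cannot be assigned to either alone, and no measurement here explains it.

Among the compounds shown here, compound 3 has no number, so no step involving cyclohex-1-en-1-yl can be read. Also open, on these data alone, is how the number would respond to a group without a ring at this place, such as an amine, a carboxylic acid or a longer chain.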